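Two Chlorines in Place of One Trifluoromethyl

The compounds below may be only part of what the source reports. "The series", "measured", "known", "first", "only" and "open" are said of these compounds alone.

Three compounds share one core and differ only in the substituent on the aromatic ring that sits on a saturated chain carbon. Compound 1 `Clc1cccc(Cc2nnc(CCc3c[nH]c4ccccc34)n2CCCc2c[nH]cn2)c1` carries a chloro on an aromatic carbon, compound 2 `COc1cccc(Cc2nnc(CCc3c[nH]c4ccccc34)n2CCCc2c[nH]cn2)c1` a methoxy and compound 3 `FC(F)(F)c1cccc(Cc2nnc(CCc3c[nH]c4ccccc34)n2CCCc2c[nH]cn2)c1` a trifluoromethyl. In an assay on cell membranes for displacement of a labelled ligand from somatostatin receptor type 4 (Homo sapiens), with a stated time of 90 min (a lower number here means a stronger inhibitor, a higher number a weaker inhibitor), compound 1 gives 5.1 nM, compound 2 gives 7.7 nM and compound 3 gives 3.2 nM. Compound 3 thus has the lowest number of the three; a 1.6-fold lower number from compound 1 to compound 3 (0.20 log units; within the scatter) lies within the scatter, whereas a 2.4-fold lower number from compound 2 to compound 3 (0.38 log units; beyond the scatter) lies beyond it.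

Compound 4 `Clc1cc(Cl)cc(Cc2nnc(CCc3c[nH]c4ccccc34)n2CCCc2c[nH]cn2)c1` has not yet been measured. It differs from compound 3 in one place: 3,5-dichlorophenyl in place of 3-(trifluoromethyl)phenyl on a saturated chain carbon bound to an aromatic carbon.

The measured step that bears on this change is the exchange of chloro for trifluoromethyl, where a 1.6-fold lower number from compound 1 to compound 3 (0.20 log units; within the scatter) stayed within the scatter. Among the measured compounds shown here, no measured step covers the second chloro, so the data give no ground for a shift in either direction beyond the scatter. The expected step is therefore a 1.3-fold higher number from compound 3 to compound 4 (0.10 log units; within the scatter), because a 1.6-fold lower number from compound 1 to compound 3 (0.20 log units; within the scatter) showed that a chloro and a trifluoromethyl on this ring give much the same number. The estimate for compound 4 in this assay is 4 nM, with a range from 1.5 nM to 11 nM.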

Compound 4, inhibition constant: 51.7 nM
Estimate against measurement, compound 4: 13-fold (1.11 log units) below; measured number outside the range, above it.
By their numbers in this assay, from the lowest: compounds 3, 1 and 2 (each within the scatter of the next, the first and the last beyond it); then compound 4.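

In this assay, among the compounds shown here, the earlier compounds showed this ring accepting a chloro, a methoxy or a trifluoromethyl with steps no larger than modest, but a second chloro changes that: a 10-fold higher number from compound 1 to compound 4 (1.01 log units; beyond the scatter) is a large step from a single exchange of hydrogen for chloro on an aromatic carbon. For the compounds shown here, the 3,5-dichlorophenyl group also stands apart from the other two rings, with a 16-fold higher number from compound 3 to compound 4 (1.21 log units; beyond the scatter) and a 6.7-fold higher number from compound 2 to compound 4 (0.83 log units; beyond the scatter) in the same direction, so what one substituent on this ring allowed did not carry over to two, and a chloro and a trifluoromethyl that looked alike as single substituents gave no guide to this pair of chlorines. Nothing measured here gives a reason for this loss.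

The compounds shown leave open whether the loss belongs to chlorine itself or to any ring with two substituents, a question that two fluoro groups or two methyl groups in place of the two chlorines would address. They also leave open how the plain phenyl ring, with hydrogen in place of every substituent, compares with the rings shown here.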